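The source may hold more compounds than are shown below. What is called first, only, known or untested is meant among the compounds shown, and "the series" means these compounds.

Compound 1 `CCOC(=O)[C@@]1(C(=O)Nc2ccccc2)C[C@@H]1c1cc(OC)c(OC)c(OC)c1` is drawn as a single mirror-image form, with both of its ring stereocentres defined. In a functional assay on A549 cells (Homo sapiens) for cytotoxicity, read by MTT assay, with a stated time of 48 h (on this read-out lower numbers stand for stronger inhibition and higher numbers for weaker inhibition), compound 1 gives > 100000 nM, which is a limit of the assay and not a number. As far as these compounds go, its true potency therefore remains unknown. Compound 3 `CCOC(=O)C1(C(=O)Nc2ccc(OC)cc2)CC1c1cc(OC)c(OC)c(OC)c1` carries one more methoxy group and gives 61400 nM; > 100000 nM (2 entries). One of these two entries is also a limit.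

Compound 4 `CCOC(=O)[C@]1(C(=O)Nc2ccccc2)C[C@H]1c1cc(OC)c(OC)c(OC)c1` has not yet been measured. It is the mirror image of compound 1: the two compounds have the same atoms and bonds and differ only in configuration as drawn: 2 of 2 stereo elements differ (all stereocentres are inverted: mirror images); a stereocentre at a saturated ring carbon is drawn S in compound 1 and R in compound 4; a stereocentre at a saturated ring carbon is drawn R in compound 1 and S in compound 4.

The best guide is compound 2 `CCOC(=O)C1(C(=O)Nc2ccccc2)CC1c1cc(OC)c(OC)c(OC)c1`, which has the same atoms and bonds as compound 1 and, unlike it, has no configuration drawn, as noted in the fact that one of compounds 1 and 2 is drawn with a defined configuration and the other without, at the place where they differ. In this assay, compound 2 gives 31500 nM; 48600 nM (2 entries), and both entries are actual numbers. If compound 2 contains both mirror images, much of its measurable activity could come from the form drawn as compound 4. A moderate step towards lower numbers, meaning stronger inhibition, is therefore expected in this assay. The expected change is an at least 4.0-fold lower number from compound 1 to compound 4 (0.60 log units; beyond the scatter). For compound 4, the estimated value is 25000 nM, with an expected range of 9000 nM to 70000 nM.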

Compound 4, half-maximal inhibitory concentration: 37300 nM
For compound 4 the middle estimate is 1.5-fold (0.17 log units) below the measured one; the measured number falls inside the stated range.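

In this assay compound 1 gives > 100000 nM, which is a limit of the assay and not a number. Inverting both ring stereocentres gives an at least 2.6-fold lower number from compound 1 to compound 4 (0.42 log units; beyond the scatter), and this change can be traced to configuration alone because nothing else in the structure differs: the fact that compounds 1 and 4 differ only in the configuration as drawn. Compound 4 gives 37300 nM and compound 2 gives 31500 nM; 48600 nM (2 entries), so the measured number of the single form lies close to those of the compound drawn without configuration, which fits the idea that the form drawn as compound 4 carries the measurable activity of compound 2, although that idea rests on a comparison of drawings and not on a known composition: the fact that one of compounds 2 and 4 is drawn with a defined configuration and the other without, at the place where they differ.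

As far as these compounds go, the true size of the gap between the two mirror images stays open, since only a lower bound on it can be read from the limit: the limit of > 100000 nM in this assay, at which 1 of the 4 values shown sits. Also open, from the compounds shown here alone, is whether the configuration of compound 4 would keep its edge if the ethyl ester were replaced by a carboxylic acid, or if the phenyl ring on the amide were replaced by a pyridine.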